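Para-substituent swaps on a diaryl urea cytotoxicity series

The compounds below may be only part of what the source reports. "The series", "measured", "known", "first", "only" and "open" are said of these compounds alone.

Measured so far:
compound 1 `Cc1cc(C)nc(Oc2ccc(NC(=O)Nc3ccc(OC(F)(F)F)cc3)cc2)n1` — 30800 nM in a functional assay on CNE-2 cells (Homo sapiens) for cytotoxicity, read by MTT assay, with a stated time of 3 days; on this read-out higher numbers stand for weaker inhibition and lower numbers for stronger inhibition
compound 2 `Cc1cc(C)nc(Oc2ccc(NC(=O)Nc3ccc(F)cc3)cc2)n1` — 46900 nM in this assay

Among the measured compounds shown here, compound 1 gives the lowest of the two numbers; its nearest neighbour is compound 2, and the only measured step, a 1.5-fold higher number from compound 1 to compound 2 (0.18 log units; within the scatter), lies within the scatter. That step is the one that bears on the unmeasured compound 3 `Cc1cc(C)nc(Oc2ccc(NC(=O)Nc3ccc(Cl)cc3)cc2)n1`, which differs from compound 1 by chloro in place of trifluoromethoxy on an aromatic carbon. In both cases the trifluoromethoxy leaves and a single substituent enters at the same place on the same ring, and the measured example of such an exchange shows no step beyond the scatter. For compound 3, therefore, no step beyond the scatter is expected in this assay. Compound 3 is expected to give 35000 nM in this assay, with a range of 15000 nM to 80000 nM. This estimate means a 1.1-fold higher number from compound 1 to compound 3 (0.06 log units; within the scatter).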

Compound 3, half-maximal inhibitory concentration: 20400 nM
Estimate against measurement, compound 3: 1.7-fold (0.23 log units) above; the range from low to high includes it.
By their numbers in this assay, from the lowest: compounds 3, 1 and 2 (each within the scatter of the next, the first and the last beyond it).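

In this assay, chloro in place of trifluoromethoxy gives a 1.5-fold lower number from compound 1 to compound 3 (0.18 log units; within the scatter), so a second exchange of the trifluoromethoxy for a single substituent on this aromatic carbon, para to a large group, also stays within the scatter. Chloro in place of fluoro at the same place gives a 2.3-fold lower number from compound 2 to compound 3 (0.36 log units; beyond the scatter), a modest step and the first here to pass the scatter, which shows that the two halogens are separated on this read-out while trifluoromethoxy lies within the scatter of both. No available evidence accounts for this difference.

Open, going by these compounds, is how an amine or a carboxylic acid at this place would read in this assay. Also open, on these data alone, is whether the step from fluoro to chloro holds when the rest of the core of compound 1 is changed.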